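Adding a Methoxy Group: an Expected Step in Growth Inhibition

This account rests on a few compounds, and the source may have more. Where it says the series, first, only, none or still open, it means among the compounds named here.

Measured compounds:
Compound 1, `O=C1C=COC(/C=C/c2ccccc2)C1`: 122 uM
Compound 2, `COc1ccc(/C=C/C2CC(=O)C=CO2)cc1`: 152 uM
Compound 3, `COc1ccc(/C=C/C2CC=CC(=O)O2)cc1OC`: 23.9 uM

All three numbers come from a functional assay on U-251 cells (Homo sapiens) for inhibition, read by sulforhodamine B assay, with a stated time of 48 h; a lower number here means a stronger inhibitor of growth, a higher number a weaker inhibitor of growth. Compound 1 and compound 2 differ in a single place: methoxy in place of hydrogen on an aromatic carbon. The step that this change made is a 1.2-fold higher number from compound 1 to compound 2 (0.10 log units; within the scatter), so the two numbers cannot be told apart. Compound 3 has the lowest number of the three, beyond the usual scatter from both compound 1 and compound 2; how its core differs from the core of compound 1 is not broken down here.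

Compound 4, `COc1cc(OC)c(OC)cc1/C=C/C1CC=CC(=O)O1`, has not yet been measured in this assay. It differs from compound 3 in one place: methoxy in place of hydrogen on an aromatic carbon. Going by the values given here, this is the same kind of change as the one from compound 1 to compound 2, but the surroundings differ. In the earlier change the methoxy sits para to a group of 9 heavy atoms; in the new one it sits ortho to a group of 9 heavy atoms, meta to a methoxy group and para to a methoxy group. Among the compounds with values here, the only guide is the earlier step, which stayed within the scatter, so the step from compound 3 to compound 4 is expected to be small as well, about a 1.3-fold higher number from compound 3 to compound 4 (0.10 log units; within the scatter), because the measured step of a 1.2-fold higher number from compound 1 to compound 2 (0.10 log units; within the scatter) showed little effect of the same kind of change. Compound 4 is therefore estimated at 30 uM in this assay, with a likely range from 10 uM to 90 uM.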

Compound 4, concentration for growth inhibition (reported as GI): 11.5 uM
Compound 4: the middle estimate sits 2.6-fold (0.42 log units) above what was measured, and the stated range covers the measured number.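

In this assay, adding the methoxy group gave a 2.1-fold lower number from compound 3 to compound 4 (0.32 log units; beyond the scatter), a modest step towards stronger growth inhibition, while the same kind of change on the other core gave a 1.2-fold higher number from compound 1 to compound 2 (0.10 log units; within the scatter), a step too small to read. Although only the newer step lies beyond the scatter, the gap between the two steps does not, so they cannot be called different: the same change on two cores in this assay, a 1.2-fold higher number (0.10 log units; within the scatter) from compound 1 to compound 2 and a 2.1-fold lower number (0.32 log units; beyond the scatter) from compound 3 to compound 4, 2.6-fold (0.41 log units) apart, within the scatter of two such steps. Going by these compounds alone, this means the series gives no firm sign that the core alters what this change does, but it does not prove that the change carries over unaltered either, since there are only two pairs and the new methoxy has its own surroundings, ortho to a group of 9 heavy atoms, meta to a methoxy group and para to a methoxy group.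

The compounds shown carry only hydrogen or methoxy on the aromatic ring, so they leave open what a hydroxyl group, a chlorine atom or a longer chain such as ethoxy would do at the same place. They also leave open what the step would be if the core of compound 1 carried the same three methoxy groups as compound 4, the comparison that would separate the effect of the core from that of the surroundings.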